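Pentafluoroethyl in Place of Methyl: Expected Lipophilicity Shift

The compounds below may be only part of what the source reports. "The series", "measured", "known", "first", "only" and "open" are said of these compounds alone.

Among the measured compounds shown here, compound 1 `Cc1n[nH]c(-c2nc(Cc3ccccc3F)c3ccccn23)n1` gives 3.3 in a physicochemical assay for lipophilicity, measured as octanol-water partition, at pH 7.4 (on this read-out higher numbers stand for higher lipophilicity and lower numbers for lower lipophilicity), the higher of the two numbers known so far. Compound 2 `Fc1ccccc1Cc1nc(-c2nc(C(F)(F)F)n[nH]2)n2cccnc12` gives 2.5 in this assay, a value that sits below compound 1 by more than the usual scatter. Compound 3 `Fc1ccccc1Cc1nc(-c2nc(C(F)(F)C(F)(F)F)n[nH]2)n2ccccc12` has not yet been measured. Compared with compound 1, it carries 1,1,2,2,2-pentafluoroethyl in place of methyl on an aromatic carbon. For the measured compounds named here, no step between measured compounds that differ in a single place is known here. The step of a number 0.90 log units higher from compound 1 to compound 3 (beyond the scatter) is expected to be upward and clearly beyond the scatter. For compound 3 the value in this assay is estimated at 4.2, with a likely range from 3.6 to 4.8.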

Compound 3, distribution coefficient: 4.2
Estimate against measurement, compound 3: no gap at the digits printed; the range from low to high includes it.
By their numbers in this assay, from the lowest: compound 2; then compound 1; then compound 3.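

In this assay, 1,1,2,2,2-pentafluoroethyl in place of methyl on this aromatic carbon, between two ring nitrogen atoms, gives a number 0.90 log units higher from compound 1 to compound 3 (beyond the scatter). Among the compounds shown here, this is the first step here that can be read at a single place, and it shows that this position responds clearly to the change. Nothing measured here explains the size of this step. On these data alone, whether the rise follows the fluorine atoms or the longer chain stays open, since a single step cannot separate them. Ethyl, an amine or a carboxylic acid on the same carbon would test how far this position can move the number in either direction.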